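This account rests on a few compounds, and the source may have more. Where it says the series, first, only, none or still open, it means among the compounds named here.

Three compounds built on one shared core were tested in an assay on CHO cells for displacement of a labelled ligand from adenosine receptor A3 (Homo sapiens), read by scintillation counting, with a stated time of 120 min, tested at 10 uM; a lower number here means less inhibition, a higher number more inhibition at the concentration tested (going by the name of the read-out). Compound 1 `Nc1scc(CN2CCN(c3ccc(Cl)cc3F)CC2)c1C(=O)c1ccc(Cl)cc1` gives 1%. Compound 2 `Nc1scc(CN2CCN(c3cccc(C(F)(F)F)c3)CC2)c1C(=O)c1ccc(Cl)cc1` gives 0%, and compound 3 `Nc1scc(CN2CCN(C3CCCCCC3)CC2)c1C(=O)c1ccc(Cl)cc1` gives 0%, so compound 3 stands level with compound 2 at the digits reported, the two together the lowest of the three numbers, while compound 1 sits only a number 1 percentage points lower from compound 1 to compound 3 (within the scatter) away. Compound 4 `Nc1scc(CN2CCN(c3cccc4ccccc34)CC2)c1C(=O)c1ccc(Cl)cc1` differs from compound 3 in one place: naphthalen-1-yl in place of cycloheptyl on an amine nitrogen in a ring. The two earlier swaps of the group on the same nitrogen, a number 1 percentage points lower from compound 1 to compound 3 (within the scatter) and no change at the digits printed from compound 2 to compound 3 (within the scatter), both stayed within the scatter, so no step beyond the scatter is expected in this assay; the expected step is a number 2 percentage points higher from compound 3 to compound 4 (within the scatter). Compound 4 is therefore estimated at 2%, with a range from -8% to 12%.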

Compound 4, a percentage reported as inhibition, at one concentration (the size of the read-out at that concentration, not a potency): 0%
The estimate for compound 4 lay 2 percentage points above the measured number, and the stated range covers the measured number.
By their numbers in this assay, from the lowest: compounds 2, 3, 4 and 1 (each within the scatter of the next).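

Naphthalen-1-yl in place of cycloheptyl on an amine nitrogen in a ring gives no change at the digits printed from compound 3 to compound 4 (within the scatter) in this assay, so at this position, 2 six-membered aromatic rings of carbon only read the same as one seven-membered non-aromatic ring. For the compounds shown here, the comparisons with the two substituted phenyl groups, no change at the digits printed from compound 2 to compound 4 (within the scatter) and a number 1 percentage points lower from compound 1 to compound 4 (within the scatter), also show no separation between compounds. No supporting data bear on this result.

Still open, as far as these compounds go, is whether a group carrying an amine or a carboxylic acid on this nitrogen, or a longer chain there, would move the number beyond the scatter.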